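The source may hold more compounds than are shown below. What is called first, only, known or untested is meant among the compounds shown, and "the series" means these compounds.

Measured compounds:
compound 1 `CCOC(=O)c1oc2ccc(NS(=O)(=O)c3ccc(C(F)(F)F)cc3)cc2c1C` — 24200 nM
compound 2 `CCOC(=O)c1oc2ccc(NS(=O)(=O)c3ccc(Cl)cc3)cc2c1C` — > 40000 nM
compound 3 `CCOC(=O)c1oc2ccc(N(Cc3ccccc3)S(=O)(=O)c3ccc(OC)cc3)cc2c1C` — > 40000 nM

In a functional assay on HCT-116 cells (Homo sapiens) for inhibition, read by MTT assay, with a stated time of 72 h (on this read-out higher numbers stand for weaker inhibition and lower numbers for stronger inhibition), compound 1 gives 24200 nM. Compound 2 reaches only the limit of the measurement, > 40000 nM. Compound 3 also stands at a limit, > 40000 nM, so no number for it is known; it shares (the limit of > 40000 nM in this assay, at which 2 of the 3 values shown sit). Compound 4 `CCOC(=O)c1oc2ccc(N(Cc3ccccc3)S(=O)(=O)c3ccc(F)cc3)cc2c1C` differs from compound 3 in one place: fluoro in place of methoxy on an aromatic carbon. Among the measured compounds shown here, the only measured step, an at least 1.6-fold higher number from compound 1 to compound 2 (0.21 log units; that floor lies within the scatter), concerns a different exchange on that aromatic carbon and does not leave the scatter, so nothing measured here bears directly on fluoro in place of methoxy. The expected step that the limit leaves unreadable from compound 3 to compound 4 is therefore none beyond the scatter, in either direction. Compound 4 is estimated at 45000 nM, between 15000 nM and 150000 nM.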

Compound 4, half-maximal inhibitory concentration: 33100 nM
Compound 4: middle estimate off by 1.4-fold (0.13 log units), on the high side, within the range that was stated.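

In this assay the step for fluoro in place of methoxy on this aromatic carbon is an at least 1.2-fold lower number from compound 3 to compound 4 (0.08 log units; that floor lies within the scatter) and no exact size can be given. Still, compound 4 has a readable number where compound 3 has only a limit. This shows that a compound with the 4-fluorophenyl group falls within the measurable range, but not that fluoro clearly outperforms methoxy: the limit of > 40000 nM in this assay, at which 2 of the 4 values shown sit.

From the compounds shown here alone, whether an amine or a nitrile on this aromatic carbon would move the number beyond the scatter stays open. So does the effect of a longer chain in place of methoxy.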